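This account rests on a few compounds, and the source may have more. Where it says the series, first, only, none or still open, it means among the compounds named here.

Measured compounds in an assay on HEK293 cells for agonist activity at Toll-like receptor 8 (Homo sapiens), read by a luciferase reporter, with a stated time of 6 h; on this read-out lower numbers stand for an effect already at smaller amounts and higher numbers for an effect only at larger amounts of compound:
- compound 1 `CCCCNc1nc(N)nc2c1CCNC2`: 0.6 uM
- compound 2 `CCCCNc1nc(N)nc2c1CCN(C(C)=O)C2`: 0.4 uM
- compound 3 `CCCCNc1nc(N)nc2c1CN(C(=O)c1ccccc1)CC2`: 1.4 uM

Compound 3 holds the highest number of the three. Against compound 1 it sits beyond the scatter, and against compound 2 further still, so the benzoyl group on the ring nitrogen is tied to a real upward shift relative to the unsubstituted and the acetylated cores. For the measured compounds named here, the one step measured within the set, a 1.5-fold lower number from compound 1 to compound 2 (0.18 log units; within the scatter), concerns a different change and lies within the scatter; it says nothing direct about exchanging one aryl group for another on the carbonyl.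

Compound 4 `CCCCNc1nc(N)nc2c1CN(C(=O)c1cocn1)CC2` is the next member. The change from compound 3 is 1,3-oxazol-4-yl in place of phenyl on a carbonyl carbon. Going by the values given here, no measured pair carries an aromatic ring swapped for another on this carbonyl, so nothing here sets the size of the step. Since compound 3 stands above both smaller acyl variants and the entering group is smaller than the leaving one, a mild move back toward the numbers of compound 1 and compound 2 is expected, though a step within the scatter is just as plausible; the estimated step is a 1.4-fold lower number from compound 3 to compound 4 (0.15 log units; within the scatter). Compound 4 is therefore expected at about 1 uM, with a range of 0.4 uM to 2.8 uM.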

Compound 4, minimum effective concentration: 0.2 uM
Compound 4: middle estimate off by 5.0-fold (0.70 log units), on the high side; measured number below the stated range.
By their numbers in this assay, from the lowest: compounds 4, 2 and 1 (each within the scatter of the next, the first and the last beyond it); then compound 3.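

In this assay, the group on the carbonyl carbon of this amide-type ring nitrogen proves to matter: 1,3-oxazol-4-yl in place of phenyl gives a 7.0-fold lower number from compound 3 to compound 4 (0.85 log units; beyond the scatter), which lies beyond the scatter. The only earlier step, a 1.5-fold lower number from compound 1 to compound 2 (0.18 log units; within the scatter), concerned a different change and stayed within the scatter, so this is the first sign in the compounds shown that a single exchange at an acyl group can move the read-out clearly. The change replaces a six-membered aromatic ring of carbon only with a five-membered aromatic ring with 2 hetero atoms, but no measurement in hand ties the step to ring size, to the hetero atoms or to any other feature of the exchange.

Still open, from the compounds shown here alone, is which of these differences carries the step, a question that groups such as furan-2-yl, pyridin-2-yl or cyclopentyl on the same carbonyl could help to answer. Going by these compounds, it is also open whether 1,3-oxazol-4-yl on a carbonyl gives a similar step on the core of compound 1, whose ring differs from that of compound 3.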